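Swapping a nitro for a methyl on the aryl end

A few compounds are considered here, and "the series" means these few. Any claim that something is new, unique, unknown or untested is made for them only; others in the source may bear on it.

Measured so far:
compound 1, `CC1=CCCC(C)(C)C1/C=C/C(=O)/C=C/c1ccccc1F`, 6000 nM
compound 2, `CC1=CCCC(C)(C)C1/C=C/C(=O)/C=C/c1cccc([N+](=O)[O-])c1`, 4000 nM

Both compounds share the same core and differ only in the group on the phenyl ring at the far end of the chain. For the measured compounds named here, in a functional assay on LNCaP C4-2B cells (Homo sapiens) for cytotoxicity, read by MTT assay, with a stated time of 72 h (a higher number here means a weaker inhibitor, a lower number a stronger inhibitor), compound 2 gives 4000 nM, the lowest of the two numbers so far, while compound 1 gives 6000 nM; the gap between them lies within the usual scatter, so the two cannot be told apart.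

Compound 3, `CC1=CCCC(C)(C)C1/C=C/C(=O)/C=C/c1cccc(C)c1`, has not yet been measured. It comes from compound 2 by methyl in place of nitro on an aromatic carbon of a six-membered aromatic ring of carbon only, meta to a large group.

Going by the values given here, no step between measured compounds is available to lean on, and the two known values sit close together. The expectation is therefore a step in this assay of no size beyond the scatter, in either direction. Compound 3 is estimated to give about 5000 nM, a step of a 1.3-fold higher number from compound 2 to compound 3 (0.10 log units; within the scatter), with a likely range from 2000 nM to 12000 nM.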

Compound 3, half-maximal inhibitory concentration: 6200 nM
The estimate for compound 3 lay 1.2-fold (0.09 log units) below the measured number; measured number inside the range.
By their numbers in this assay, from the lowest: compounds 2, 1 and 3 (each within the scatter of the next).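

In this assay, for the compounds shown here, putting a methyl where the nitro stood on an aromatic carbon, meta to a large group, gives a 1.6-fold higher number from compound 2 to compound 3 (0.19 log units; within the scatter) and so produces no step that can be told apart from repeat-measurement noise, even though a group with nitrogen, oxygen and hydrogen-bond acceptors leaves and a lone carbon without any acceptor enters. Changing the whole aryl end, with 3-methylphenyl in place of 2-fluorophenyl, gives a 1.0-fold higher number from compound 1 to compound 3 (0.01 log units; within the scatter) and is equally unreadable, so all three aryl ends seen so far remain indistinguishable in this cell assay. No separate measurement is available that could explain why these compounds lie so close together.

As far as these compounds go, it remains open whether a quite different group on this aromatic carbon, such as an amine, a carboxylic acid or a longer chain in place of the methyl, would produce a step beyond the scatter. From the compounds shown here alone, it also remains open whether any change to the shared core would move the number more than these changes at the aryl end have.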